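The compounds below may be only part of what the source reports. "The series", "measured", "known", "first", "only" and "open" are said of these compounds alone.

Compound 1 `Cc1ccc(S(=O)(=O)N(Cc2ccccc2)Cc2cccc(F)c2F)cc1`: -35.7%
Compound 2 `O=S(=O)(c1ccc(F)cc1)N(Cc1cccc(F)c1F)Cc1cn(S(=O)(=O)c2ccc(F)cc2)c2ccccc12`: -20%
Compound 3 `Cc1ccc(S(=O)(=O)N(Cc2cn(Cc3cc(F)ccc3F)nn2)Cc2cn(S(C)(=O)=O)c3ccccc23)cc1`: 3.4%

In a functional assay on 3T3-L1 cells (Mus musculus) for inhibition, with a stated time of 20 min, tested at 20 uM (on this read-out higher numbers stand for more inhibition at the one concentration tested (going by the name of the read-out) and lower numbers for less inhibition), compound 2 stands second highest of the three numbers: compound 1 gives a value lower by a margin beyond the usual scatter, and compound 3 gives a value higher, also beyond the scatter. Compound 4 `CC(=O)N(Cc1cccc(F)c1F)Cc1cn(S(=O)(=O)c2ccc(F)cc2)c2ccccc12` differs from compound 2 in one place: acetyl in place of (4-fluorophenyl)sulfonyl on an amine nitrogen. Among the measured compounds shown here, no pair of measured compounds isolates this kind of change, so there is no step to lean on. All three measured values sit near or below zero in this assay, and the change is expected to move the number little, if at all, beyond the scatter. Compound 4 is therefore expected to give -12%, in a range from -40% to 15%, a step of a number 8 percentage points higher from compound 2 to compound 4 (within the scatter) that is expected to stay within the scatter.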

Compound 4, a percentage reported as inhibition, at one concentration (the size of the read-out at that concentration, not a potency): 25.8%
Compound 4: middle estimate off by 37.8 percentage points, on the low side, outside the stated range (above it).
By their numbers in this assay, from the lowest: compound 1; then compound 2; then compound 3; then compound 4.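

In this assay, putting acetyl in place of (4-fluorophenyl)sulfonyl on the amine nitrogen gives a number 45.8 percentage points higher from compound 2 to compound 4 (beyond the scatter) and so shows that this position is not indifferent to what it carries. Among the compounds shown here, this is the first comparison in the set that changes one place only, and the entering group has no ring where the leaving group has a six-membered aromatic one. Nothing at hand explains the shift.

This single pair cannot tell whether the gain belongs to the acetyl itself or to the loss of the ring. On these data alone, how a butanoyl chain or a benzoyl group on that nitrogen would read remains open.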